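This account rests on a few compounds, and the source may have more. Where it says the series, first, only, none or still open, it means among the compounds named here.

Compound 1, `COc1ccc(/C=C/C2CC=CC(=O)O2)cc1`, is measured in a functional assay on OVCAR-3 cells (Homo sapiens) for inhibition, read by sulforhodamine B assay, with a stated time of 48 h; on this read-out lower numbers stand for stronger inhibition of growth and higher numbers for weaker inhibition of growth. In this assay compound 1 gives 61.5 uM. Compound 2, `COc1ccc(/C=C/C2CC=CC(=O)O2)cc1OC`, differs from it in one place:

methoxy in place of hydrogen on an aromatic carbon

In this assay compound 2 gives 16.8 uM. That change produced a 3.7-fold lower number from compound 1 to compound 2 (0.56 log units; beyond the scatter).

Compound 3, `COc1ccc(/C=C/C2CC=CC(=O)N2)cc1`, has a different core from compound 1; the difference between the two cores is not broken down here. In this assay compound 3 gives 787 uM, the highest of the three numbers, with compound 1 a step beyond the scatter lower and compound 2 further still.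

Compound 4, `COc1ccc(/C=C/C2CC=CC(=O)N2)c(OC)c1`, has not yet been measured. It differs from compound 3 as follows:

methoxy in place of hydrogen on an aromatic carbon

This is the same kind of change as that from compound 1 to compound 2, though not the same: in compound 2 the entering methoxy sits ortho to a methoxy group and meta to a group of 9 heavy atoms, whereas in compound 4 it sits ortho to a group of 9 heavy atoms and meta to a methoxy group. Because compound 1 to compound 2 gave a 3.7-fold lower number from compound 1 to compound 2 (0.56 log units; beyond the scatter), a step of roughly similar size, a 2.6-fold lower number from compound 3 to compound 4 (0.42 log units; beyond the scatter), is expected for compound 4 in this assay, with wide uncertainty given the changed surroundings. The estimate for compound 4 is therefore 300 uM, expected to lie between 100 uM and 900 uM.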

Compound 4, concentration for growth inhibition (reported as GI): > 964 uM
Compound 4 was reported as a limit; the forecaster's own chance of this, stated with the estimate: 15%; middle value at least 3.2-fold (0.50 log units) from the limit.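

In this assay the methoxy step on the core of compound 3 is an at least 1.2-fold higher number from compound 3 to compound 4 (0.08 log units; that floor lies within the scatter), and that figure is only a floor. Compound 4 is reported as a limit and not as a number: the limit of > 964 uM in this assay, at which 1 of the 4 values shown sits. The change therefore does not carry over as a fixed step from one core to the other, but this does not show how large the step on the core of compound 3 really is, nor does it separate the change of core from the different place of the methoxy, which in compound 4 sits ortho to a group of 9 heavy atoms: the same change on two cores in this assay, a 3.7-fold lower number (0.56 log units; beyond the scatter) from compound 1 to compound 2 and an at least 1.2-fold higher number (0.08 log units; that floor lies within the scatter) from compound 3 to compound 4, at least 4.4-fold (0.65 log units) apart, beyond the scatter of two such steps.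

The compounds shown leave open whether methoxy would act alike on both cores if it sat in the same place on each. They also leave open how a different group on that aromatic carbon, such as an amine or a carboxylic acid, would compare with methoxy on either core.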